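Dimethoxyphenyl in place of indolyl at the ketone

The source may report more compounds than this note shows. Statements on the series, on what has been measured and on what is new or still open speak of the compounds shown alone.

Measured so far in a functional assay on Huh-7 cells (Homo sapiens) for inhibition, read by sulforhodamine B assay, with a stated time of 72 h; on this read-out higher numbers stand for weaker inhibition and lower numbers for stronger inhibition:
compound 1 `COc1ccc(OC)c(C(=O)/C=C/c2cn(-c3ccccc3)nc2-c2ccsc2)c1` — 2100 nM
compound 2 `COc1ccc(C(=O)/C=C/c2cn(-c3ccccc3)nc2-c2ccsc2)c(OC)c1` — 3000 nM
compound 3 `O=C(/C=C/c1cn(-c2ccccc2)nc1-c1cccnc1)c1c[nH]c2ccccc12` — 3200 nM

Compound 3 sits alongside compound 2 and compound 1 in this assay; all three numbers lie within the usual scatter of one another, so no ranking among them can be read. The next compound is compound 4 `COc1ccc(C(=O)/C=C/c2cn(-c3ccccc3)nc2-c2cccnc2)cc1OC`, which differs from compound 3 by 3,4-dimethoxyphenyl in place of 1H-indol-3-yl on a carbonyl carbon. Going by the values given here, the only measured step of related kind, a 1.4-fold higher number from compound 1 to compound 2 (0.15 log units; within the scatter), moved the number by an amount within the scatter when one dimethoxyphenyl pattern replaced another. Among the compounds with values here, no measured step exchanges indol-3-yl for a dimethoxyphenyl, so the expectation rests on the narrow spread seen across all three compounds. Compound 4 is therefore expected to give 2600 nM, between 1200 nM and 5500 nM, a step of a 1.2-fold lower number from compound 3 to compound 4 (0.09 log units; within the scatter) that is expected to stay within the scatter.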

Compound 4, half-maximal inhibitory concentration: 3100 nM
Estimate against measurement, compound 4: 1.2-fold (0.08 log units) below; low and high end bracket the measured number.
By their numbers in this assay, from the lowest: compounds 1, 2, 4 and 3 (each within the scatter of the next).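

In this assay, the exchange of 1H-indol-3-yl for 3,4-dimethoxyphenyl on the carbonyl carbon gives a 1.0-fold lower number from compound 3 to compound 4 (0.01 log units; within the scatter) and leaves no readable difference. The earlier step compared only two dimethoxyphenyl patterns, whereas this one replaces a two-ring group carrying a hydrogen-bond donor with a one-ring group carrying no donor and two acceptors, and the number still holds within the scatter. No available evidence bears on the reason for this result.

Still open, as far as these compounds go, is whether a non-aromatic group on the carbonyl carbon, such as a simple amine or a carboxylic acid, would shift the number beyond the scatter.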